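This account rests on a few compounds, and the source may have more. Where it says the series, first, only, none or still open, it means among the compounds named here.

Measured compounds, all read in a functional assay, read by spectrophotometry, with a stated time of 15 min, tested at 100 ug/mL; on this read-out lower numbers stand for a weaker effect and higher numbers for a stronger effect at the one concentration tested:
Compound 1 `Fc1ccc(-c2csc(N/N=C/c3ccc(Cl)cc3Cl)n2)cc1` gives 96%.
Compound 2 `COC(=O)c1cc(-c2csc(N/N=C/c3ccc(Cl)cc3Cl)n2)ccc1OCc1ccccc1` gives 56.1%.
Compound 3 `Cc1ccc(-c2csc(N/N=C/c3cccs3)n2)cc1` gives 98.1%.

Within this set compound 1 holds the second highest of the three numbers. Compound 3 lies nearest, with a number higher by an amount within the scatter, so no order between compound 1 and compound 3 can be drawn. Compound 2 lies furthest, its number lower by an amount beyond the scatter. For the measured compounds named here, no pair of measured compounds differs in a single place, so no measured step exists for the change considered here.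

Compound 4 `COc1ccc(-c2csc(N/N=C/c3ccc(Cl)cc3Cl)n2)cc1` is not yet measured. Compared with compound 1 it shows (methoxy in place of fluoro on an aromatic carbon). Nothing in the measured set tests this substituent directly.

In this assay the step is expected to be small, downward if anything, and likely to stay within the scatter, since compound 1 already sits high with 96% and compound 3, carrying a different small group on the same kind of ring, gives 98.1%. For compound 4 the expected value is 90%, with a range of 72% to 98%. The estimated step is a number 6 percentage points lower from compound 1 to compound 4 (within the scatter), within the scatter.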

Compound 4, a percentage reported as inhibition, at one concentration (the size of the read-out at that concentration, not a potency): 93.3%
Compound 4: middle estimate off by 3.3 percentage points, on the low side; the range from low to high includes it.
By their numbers in this assay, from the lowest: compound 2; then compounds 4, 1 and 3 (each within the scatter of the next).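

In this assay, for the compounds shown here, the change from 4-fluorophenyl to 4-methoxyphenyl gives the first measured single-place step (a number 2.7 percentage points lower from compound 1 to compound 4 (within the scatter)). This position therefore tolerates methoxy in place of fluoro, including the hydrogen-bond acceptor that enters with it, with no change that can be read beyond the scatter at the one concentration tested. No measured information on the compounds accounts for this outcome.

Still open, as far as these compounds go, is whether an amine, a carboxylic acid or a longer chain such as butoxy on this same aromatic carbon would also leave the number within the scatter of compound 1, or would move it beyond that. With one concentration as the only read-out, any difference in potency between the two compounds also remains unresolved.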